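Ester chain length and cytotoxicity readout in the series

The source may report more compounds than this note shows. Statements on the series, on what has been measured and on what is new or still open speak of the compounds shown alone.

Within the data shown here, compound 1 `CCOC(=O)CCC(=O)N1CCN(CCCOc2cc3c(Nc4ccc(F)c(Cl)c4)ncnc3cc2OC)CC1` gives 77.6% in a functional assay on A549 cells (Homo sapiens) for cytotoxicity, read by MTT assay, with a stated time of 24 h, tested at 10 uM (on this read-out higher numbers stand for a weaker effect at the one concentration tested and lower numbers for a stronger effect), the lower of the two numbers so far; compound 2 `CCCCOC(=O)CCC(=O)N1CCN(CCCOc2cc3c(Nc4ccc(F)c(Cl)c4)ncnc3cc2OC)CC1` gives 94.4%. Among the measured compounds shown here, the only measured step, a number 16.8 percentage points higher from compound 1 to compound 2 (beyond the scatter), comes with ethyl in place of hydrogen on a saturated chain carbon, two bonds along the chain from an oxygen next to a carbonyl group. Compound 3 `CCCCCCCCCCCOC(=O)CCC(=O)N1CCN(CCCOc2cc3c(Nc4ccc(F)c(Cl)c4)ncnc3cc2OC)CC1` carries the change nonyl in place of hydrogen on a saturated chain carbon, two bonds along the chain from an oxygen next to a carbonyl group at that same place. Since compound 2 showed the step of a number 16.8 percentage points higher from compound 1 to compound 2 (beyond the scatter), a further rise toward a weaker effect is expected for the longer chain. For compound 3 the estimate is 92%, ranging from 78% to 104%, a step of a number 14.4 percentage points higher from compound 1 to compound 3 (beyond the scatter).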

Compound 3, a percentage reported as activity, at one concentration (the size of the read-out at that concentration, not a potency): 93.4%
The estimate for compound 3 lay 1.4 percentage points below the measured number, and the stated range covers the measured number.
By their numbers in this assay, from the lowest: compound 1; then compounds 3 and 2 (each within the scatter of the next).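

Nonyl at this place also gives a number 15.8 percentage points higher from compound 1 to compound 3 (beyond the scatter) in this assay, so the separation from compound 1 persists with a much longer chain. Heptyl further out gives a number 1 percentage points lower from compound 2 to compound 3 (within the scatter), so among these three compounds, extending the chain beyond that of compound 2 brings no difference that can be separated from the scatter. Nothing measured here explains this behaviour of the chain.

Still open, going by these compounds, is whether a methyl ester, a carboxylic acid or an amine in place of the ester would give a number lower than that of compound 1.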